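This account rests on a few compounds, and the source may have more. Where it says the series, first, only, none or still open, it means among the compounds named here.

Compound 1 `O=[N+]([O-])c1ccc(/C=C/[C@@H]2CCCCN2)cc1` gives 1.02 ug/mL in a functional assay on OVCAR-3 cells (Homo sapiens) for inhibition, read by MTT assay, with a stated time of 24 h; a lower number here means a stronger inhibitor, a higher number a weaker inhibitor.
Compound 2 `C(=C/[C@@H]1CCCCN1)\c1ccccc1` gives 10.5 ug/mL in this assay.

Among the compounds with values here, compound 2 holds the higher of the two numbers; the single measured step, a 10-fold higher number from compound 1 to compound 2 (1.01 log units; beyond the scatter), is large. Compound 3 `COc1ccccc1/C=C/[C@@H]1CCCCN1` carries the change (methoxy in place of hydrogen on an aromatic carbon). Within the data shown here, no measured step adds a group to the shared core, and the removal of nitro in a 10-fold higher number from compound 1 to compound 2 (1.01 log units; beyond the scatter) is the only guide, concerning a different group. The step of a 1.5-fold lower number from compound 2 to compound 3 (0.18 log units; within the scatter) is therefore expected to be small, at most a modest lowering. Compound 3 is estimated at 7 ug/mL, with a range of 2.5 ug/mL to 25 ug/mL.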

Compound 3, half-maximal inhibitory concentration: 4.78 ug/mL
Estimate against measurement, compound 3: 1.5-fold (0.17 log units) above; the measured number falls inside the stated range.
By their numbers in this assay, from the lowest: compound 1; then compound 3; then compound 2.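

Methoxy on an aromatic carbon, ortho to a group of 8 heavy atoms, gives a 2.2-fold lower number from compound 2 to compound 3 (0.34 log units; beyond the scatter) in this assay. Within the data shown here, this is the first measured step that adds a group to the shared core, and a group other than nitro also lowers the number, though the step is only modest. Nothing measured here accounts for this step.

The compounds shown leave open whether methoxy elsewhere on the aromatic ring gives the same step. Also open, as far as these compounds go, is how hydroxyl, an amine or a longer alkoxy chain would compare with methoxy at this place.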